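The source may report more compounds than this note shows. Statements on the series, on what has been measured and on what is new or still open speak of the compounds shown alone.

Measured compounds:
Compound 1 `CC(C)c1cccc(C(C)C)c1NC(=O)NCC1(c2cccc3ccccc23)CCCC1` with 34 nM in an assay on microsomes from intestine for inhibition of acyl-CoA:cholesterol acyltransferase (Oryctolagus cuniculus); on this read-out higher numbers stand for weaker inhibition and lower numbers for stronger inhibition.
Compound 2 `COc1ccccc1NC(=O)NCC1(c2ccccc2)CCCCC1` with 270 nM in this assay.

Of these two numbers, compound 2 has the higher one, which on this read-out means the weaker inhibition; compound 1 sits well apart from it, and the gap between them lies beyond the usual scatter. Compound 2 is therefore the starting point for the next step.

Compound 3 `O=C(NCC1(c2ccccc2)CCCCC1)Nc1cccc(Cl)c1Cl` has not yet been measured in this assay. It differs from compound 2 in one place: 2,3-dichlorophenyl in place of 2-methoxyphenyl on an amide-type nitrogen. In plain words, the group attached to the urea nitrogen changes from a 2-methoxyphenyl to a 2,3-dichlorophenyl, while the rest of the molecule stays the same.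

Going by the values given here, no measured pair shows this exact exchange, so the direction must be judged from the two numbers at hand alone. A modest step toward a lower number is expected, roughly at the edge of the scatter rather than clearly beyond it. Compound 3 is thus estimated at 150 nM, within a range of 50 nM to 500 nM, which means an expected step of a 1.8-fold lower number from compound 2 to compound 3 (0.26 log units; within the scatter).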

Compound 3, half-maximal inhibitory concentration: 1300 nM
Estimate against measurement, compound 3: 8.7-fold (0.94 log units) below; measured number outside the range, above it.
By their numbers in this assay, from the lowest: compound 1; then compound 2; then compound 3.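

Going by these compounds alone, the exchange on the amide-type nitrogen gives the first comparison in which only one place changes: in this assay, 2,3-dichlorophenyl in place of 2-methoxyphenyl gives a 4.8-fold higher number from compound 2 to compound 3 (0.68 log units; beyond the scatter), which means weaker inhibition. Compound 1 differs from compound 2 in more than one place, so the earlier numbers could not single out this group. The result shows that inhibition responds to this group even though both groups have the same number of heavy atoms and a six-membered aromatic ring of carbon only, but nothing at hand gives a reason for the change.

On these data alone, the exchange removes the methoxy group and adds two chlorine atoms in a single step, so the contribution of each part stays open. A plain phenyl group or a methylphenyl group on the same nitrogen, with the rest of the molecule unchanged, would be among the comparisons needed to tell these contributions apart.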